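This account rests on a few compounds, and the source may have more. Where it says the series, first, only, none or still open, it means among the compounds named here.

Compound 1, `Cc1nc(S(C)(=O)=O)ccc1Oc1ncnc(OC2CCN(C(=O)OC(C)C)CC2)c1F`, gives 142 nM in a functional assay on isolated protein for inhibition of Glucose-dependent insulinotropic receptor (Rattus norvegicus), read by HTRF and cAMP accumulation; a lower number here means that less compound is needed, a higher number that more compound is needed for the effect.
Compound 2, `Cc1nc(S(C)(=O)=O)ccc1Oc1ncnc(OC2CCN(C(=O)SC(C)C)CC2)c1F`, gives 41.3 nM in this assay.

Going by the values given here, compound 2 stands at the lower of the two numbers, and the single measured step, a 3.4-fold lower number from compound 1 to compound 2 (0.54 log units; beyond the scatter), is a modest one. Compound 3, `Cc1nc(S(C)(=O)=O)ccc1Oc1ncnc(OC2CCN(C(=O)SC3CC3)CC2)c1F`, differs from compound 2 by cyclopropyl in place of isopropyl on a sulfur. Among the compounds with values here, no measured step touches this part of the molecule, so the one step recorded offers only a weak guide; the change from one three-carbon group to another is expected to give a step of a 1.1-fold higher number from compound 2 to compound 3 (0.04 log units; within the scatter), within the scatter. Compound 3 is therefore estimated at 45 nM, with a range from 18 nM to 110 nM.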

Compound 3, half-maximal effective concentration: 126 nM
Compound 3: middle estimate off by 2.8-fold (0.45 log units), on the low side, outside the stated range (above it).
By their numbers in this assay, from the lowest: compound 2; then compounds 3 and 1 (each within the scatter of the next).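

The group on the sulfur matters in this assay: two groups of three carbons are not interchangeable here, as cyclopropyl in place of isopropyl gives a 3.1-fold higher number from compound 2 to compound 3 (0.48 log units; beyond the scatter). The advantage seen with the sulfur therefore does not carry over to every group, since changing both the oxygen and the isopropyl together gives a 1.1-fold lower number from compound 1 to compound 3 (0.05 log units; within the scatter). Nothing available explains this difference.

The compounds shown leave open whether the ring itself or its size sets the result, which a cyclobutyl group on the sulfur could help test. They also leave open how cyclopropyl behaves on an oxygen in place of the sulfur.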